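The source may report more compounds than this note shows. Statements on the series, on what has been measured and on what is new or still open speak of the compounds shown alone.

Measured so far in an ADME assay on microsomes from liver (Homo sapiens) for metabolic stability, read by LC-MS, with stated times of 10 min and 20 min, tested at 1 uM; a lower number here means that less of the compound is left, a higher number that more of the compound is left:
- compound 1 `CCc1ccc(-c2cc(NCC3CCN(C)CC3)c3cc(OC)c(OCCCN4CCCC4)cc3n2)o1` gives 69%
- compound 2 `COc1cc2c(NC3CC4(CCN(C)CC4)C3)cc(-c3ccc(C)o3)nc2cc1OCCCN1CCCC1` gives 68.6%

In this assay compound 2 gives 68.6% and stands within the scatter of compound 1 at 69% in this series of two numbers. Still unmeasured is compound 3 `COc1cc2c(NC3CCC34CCN(C)CC4)cc(-c3ccc(C)o3)nc2cc1OCCCN1CCCC1`, which has the same atoms as compound 2, joined differently. The structural change is a group of 10 heavy atoms (9 carbon, 1 nitrogen; one four-membered non-aromatic ring of carbon only, one six-membered non-aromatic ring with 1 hetero atom) in place of a group of 10 heavy atoms (9 carbon, 1 nitrogen; one four-membered non-aromatic ring of carbon only, one six-membered non-aromatic ring with 1 hetero atom), on a nitrogen on an aromatic ring and it leaves the rest of the molecule untouched. For the measured compounds named here, no step between measured compounds that differ in one place is available, so the size of this change has no direct precedent in the data. Going by the values given here, the only guide is that compound 2 at 68.6% and compound 1 at 69% lie within the scatter of each other. On that thin basis, the expected change is a number 1.6 percentage points lower from compound 2 to compound 3 (within the scatter) and it is not expected to go beyond the scatter, with no firm direction. Compound 3 is estimated at 67% in this assay, with 50% to 82% as the expected range.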

Compound 3, percent of the compound remaining: 80.4%
Compound 3: the middle estimate sits 13.4 percentage points below what was measured; measured number inside the range.
By their numbers in this assay, from the lowest: compounds 2 and 1 (each within the scatter of the next); then compound 3.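

In this assay, for the compounds shown here, the exchange of one group for another on a nitrogen on an aromatic ring gives a number 11.8 percentage points higher from compound 2 to compound 3 (beyond the scatter) and this is the first step that can be read at this place. The two groups match in everything counted for them: 10 heavy atoms each, one four-membered non-aromatic ring of carbon only, one six-membered non-aromatic ring with 1 hetero atom, the same donors and acceptors and no net charge. The number left in this read-out therefore moves beyond the scatter with the way the same atoms are joined alone, so these counts do not settle the outcome at this place, and no measurement at hand bears on why the number moves.

Going by these compounds alone, only this one pair speaks to the change, so it remains open whether the step holds on other parts of the shared core or with a different substituent on the furan-free parts of the molecule. Also open, going by these compounds, is how a morpholine ring or an open-chain dimethylamino group on the same nitrogen would read in this assay against compound 3 at 80.4% in the same test.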